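Swapping 4-Methoxyphenyl for 1-Benzothiophen-3-yl

The source may report more compounds than this note shows. Statements on the series, on what has been measured and on what is new or still open speak of the compounds shown alone.

Measured in a functional assay on MCF7 cells (Homo sapiens) for inhibition, read by MTT assay, with a stated time of 72 h; on this read-out lower numbers stand for stronger inhibition and higher numbers for weaker inhibition:
- compound 1 `Cc1cc(Nc2cc(-c3ccccc3)[nH]n2)n2nc(SCC3CCCCC3)nc2n1`: > 50000 nM
- compound 2 `Cc1cc(Nc2cc(-c3ccccc3)[nH]n2)n2nc(SCc3ccc(Br)cc3)nc2n1`: 2720 nM
- compound 3 `COc1ccc(CSc2nc3nc(C)cc(Nc4cc(-c5ccccc5)[nH]n4)n3n2)cc1`: 4020 nM

The entry for compound 1 is a limit of the assay, not a number.

Compound 3 stands level with its nearest neighbour within the scatter, as a 1.5-fold higher number from compound 2 to compound 3 (0.17 log units; within the scatter) shows. The next molecule, compound 4 `Cc1cc(Nc2cc(-c3ccccc3)[nH]n2)n2nc(SCc3csc4ccccc34)nc2n1`, carries 1-benzothiophen-3-yl in place of 4-methoxyphenyl on a saturated chain carbon bound to a sulfur.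

Among the measured compounds shown here, three measured steps bear on this change. Replacing cyclohexyl with an aromatic group gave two large steps, an at least 18-fold lower number from compound 1 to compound 2 (1.26 log units; beyond the scatter) and an at least 12-fold lower number from compound 1 to compound 3 (1.09 log units; beyond the scatter). Exchanging one substituent on the aromatic ring gave only the small step already noted. Compound 4 keeps an aromatic group at this place, so no change beyond the scatter is expected in this assay, although this two-ring group has not been tested.

The expected step is a 1.1-fold lower number from compound 3 to compound 4 (0.06 log units; within the scatter).

For compound 4 the estimated value is 3500 nM, with an expected range from 1200 nM to 12000 nM.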

Compound 4, half-maximal inhibitory concentration: 3470 nM
Compound 4: middle estimate off by 1.0-fold (0.00 log units), on the high side, and the stated range covers the measured number.
By their numbers in this assay, from the lowest: compounds 2, 4 and 3 (each within the scatter of the next). At a limit, above all of these: compound 1.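

In this assay, a larger aromatic group with two rings, one of them a five-membered ring holding a sulfur, sits on the saturated chain carbon bound to a sulfur without moving the result beyond the scatter: the readings are a 1.2-fold lower number from compound 3 to compound 4 (0.06 log units; within the scatter) and a 1.3-fold higher number from compound 2 to compound 4 (0.11 log units; within the scatter). The contrast with cyclohexyl therefore now holds for three different aromatic groups, the newest being an at least 14-fold lower number from compound 1 to compound 4 (1.15 log units; beyond the scatter). Compound 1 stands at a limit, so the true size of that step stays unknown: the limit of > 50000 nM in this assay, at which 1 of the 4 values shown sits.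

The compounds shown leave open whether a non-aromatic group such as an amine or a carboxylic acid could also serve on this chain carbon. They also leave open what a longer chain bound to the sulfur, carrying these same aromatic groups, would give.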